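This account rests on a few compounds, and the source may have more. Where it says the series, first, only, none or still open, it means among the compounds named here.

Of the compounds shown here, three have so far been tested in a functional assay on A375P cells (Homo sapiens) for antiproliferative activity; a lower number here means a stronger inhibitor, a higher number a weaker inhibitor. Compound 1, `CC(=O)Nc1cc(NC(=O)Nc2ccc(Cl)c(Cl)c2)ccc1C`, gives 2100 nM. Compound 2, `CC(=O)Nc1cc(NC(=O)Nc2ccc(Cl)nc2)ccc1C`, gives 1100 nM. Compound 3, `CC(=O)Nc1cc(NC(=O)c2cc(=O)c3ccccc3o2)ccc1C`, is reported only as a limit of the assay, > 30000 nM, so no exact number is known for it. Compound 3 therefore sits at the limit of > 30000 nM in this assay, at which 1 of the 3 values shown sits, which is where it stands among the numbers shown.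

Compound 4, `Cc1ccc(NC(=O)c2cc(=O)c3ccccc3o2)cc1NC(=O)c1ccccc1`, has not yet been measured. It differs from compound 3 in one place: phenyl in place of methyl on a carbonyl carbon. Among the compounds with values here, no pair of measured compounds shows what such a change does here, so there is no measured step to lean on. The expected step is a number no higher from compound 3 to compound 4 (the limit leaves the size open), which means no change beyond the usual scatter of this assay. Compound 4 is accordingly estimated at 30000 nM, within a range from 8000 nM to 100000 nM. For compound 4 there is a fair chance that this assay again reports only a limit rather than a number.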

Compound 4, half-maximal inhibitory concentration: > 30000 nM
Compound 4 gave a limit, no number; the forecaster's own chance of this, stated with the estimate: 65%; the middle value sits exactly at the limit.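

Compound 3 and compound 4 each give only a limit of the assay, not a number, so no step can be read between them. The compounds shown leave open whether phenyl in place of methyl on a carbonyl carbon changes the activity at all.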